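The source may hold more compounds than are shown below. What is called first, only, known or untested is meant among the compounds shown, and "the series" means these compounds.

Measured in a functional assay on HepG2 cells (Homo sapiens) for antiproliferative activity, read by MTT assay, with a stated time of 48 h; a lower number here means a stronger inhibitor, a higher number a weaker inhibitor:
Compound 1 `COc1cc(-c2nnc(SCC(=O)c3ccccc3)n2N)cc(OC)c1OC` gives 7800 nM.
Compound 2 `COc1cc(-c2nnc(SCC(=O)c3ccc(C)cc3)n2N)cc(OC)c1OC` gives only a limit, > 100000 nM.
Compound 3 `COc1cc(-c2nnc(SCC(=O)c3ccc(F)cc3)n2N)cc(OC)c1OC` gives 90400 nM.

Compound 3 holds the highest of the two numbers shown; the nearest is compound 1, with a 12-fold higher number from compound 1 to compound 3 (1.06 log units; beyond the scatter). The shared core stays the same, and the change to compound 4 `COc1cc(-c2nnc(SCC(=O)c3cccc(Br)c3)n2N)cc(OC)c1OC` is 3-bromophenyl in place of 4-fluorophenyl on a carbonyl carbon. Going by the values given here, no measured step places a bromo on that phenyl, nor any substituent at that place. Among the compounds with values here, two steps bear loosely on it: an at least 12-fold higher number from compound 1 to compound 2 (1.10 log units; beyond the scatter) and a 12-fold higher number from compound 1 to compound 3 (1.06 log units; beyond the scatter) both show a large rise on adding a substituent to the phenyl, while an at least 1.1-fold lower number from compound 2 to compound 3 (0.04 log units; that floor lies within the scatter) shows little difference between those two substituents. Compound 4 carries a substituent as well, so it is expected to stay at a similar level, a 1.1-fold lower number from compound 3 to compound 4 (0.05 log units; within the scatter). The estimate for compound 4 is 80000 nM, expected between 20000 nM and 300000 nM.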

Compound 4, half-maximal inhibitory concentration: 56000 nM
Estimate against measurement, compound 4: 1.4-fold (0.15 log units) above; the measured number falls inside the stated range.
By their numbers in this assay, from the lowest: compound 1; then compounds 4 and 3 (each within the scatter of the next). At a limit, above all of these: compound 2.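

The 3-bromophenyl group shows that a substituent at a second place on the phenyl also keeps the number beyond the scatter of the unsubstituted compound, although the step is modest: a 7.2-fold higher number from compound 1 to compound 4 (0.86 log units; beyond the scatter). Exchanging 4-fluorophenyl for 3-bromophenyl changes both the halogen and its place, yet the step stays within the scatter: a 1.6-fold lower number from compound 3 to compound 4 (0.21 log units; within the scatter). The step from the methyl compound rests on a limit and can be read only as a floor: an at least 1.7-fold lower number from compound 2 to compound 4 (0.25 log units; that floor lies within the scatter). Compound 2 gives that limit: the limit of > 100000 nM in this assay, at which 1 of the 4 values shown sits.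

The compounds shown leave open whether the bromo or its place matters more. They also leave open whether an amine or a carboxylic acid on this phenyl would stay near compound 1.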